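Chloro to trifluoromethoxy on the aryl ring of compound 1

This account rests on a few compounds, and the source may have more. Where it says the series, first, only, none or still open, it means among the compounds named here.

Measured so far in a functional assay on DU-145 cells (Homo sapiens) for inhibition, read by trypan blue exclusion, with a stated time of 96 h; a lower number here means a stronger inhibitor of growth, a higher number a weaker inhibitor of growth:
compound 1 `O=C(/C(=C\c1ccc(Cl)cc1)S(=O)(=O)c1ccc(Br)cc1)c1ccc(Br)cc1` gives 50000 nM
compound 2 `O=C(/C(=C\c1ccc(Br)c(O)c1)S(=O)(=O)c1ccc(Br)cc1)c1ccc(Br)cc1` gives 50000 nM
compound 3 `O=C(/C(=C\c1ccc(Cl)c([N+](=O)[O-])c1)S(=O)(=O)c1ccc(Br)cc1)c1ccc(Br)cc1` gives 10000 nM

Compound 1 stands level with compound 2, the two together at the high end of the three numbers: no change at the digits printed from compound 1 to compound 2 (within the scatter). Compound 3 sits apart from both, a 5.0-fold lower number from compound 1 to compound 3 (0.70 log units; beyond the scatter) and a 5.0-fold lower number from compound 2 to compound 3 (0.70 log units; beyond the scatter).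

Compound 4 `O=C(/C(=C\c1ccc(OC(F)(F)F)cc1)S(=O)(=O)c1ccc(Br)cc1)c1ccc(Br)cc1` is the next step from compound 1: trifluoromethoxy in place of chloro on an aromatic carbon. Within the data shown here, no measured step introduces trifluoromethoxy. The swap from compound 1 to compound 2 on this ring left the number where it was, and only the nitro entry from compound 1 to compound 3 moved it, modestly. With nothing closer to go on, the step of a 1.4-fold lower number from compound 1 to compound 4 (0.15 log units; within the scatter) is expected to stay within the scatter or at most be modest. Compound 4 is therefore estimated at 35000 nM, with a range from 12000 nM to 100000 nM.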

Compound 4, concentration for 50% growth inhibition: 25000 nM
The estimate for compound 4 lay 1.4-fold (0.15 log units) above the measured number; low and high end bracket the measured number.
By their numbers in this assay, from the lowest: compound 3; then compounds 4, 1 and 2 (each within the scatter of the next).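

In this assay, replacing chloro with trifluoromethoxy on the aromatic carbon para to a large group gives a 2.0-fold lower number from compound 1 to compound 4 (0.30 log units; within the scatter). Among these compounds, at this position, a group of 5 heavy atoms with 1 hydrogen-bond acceptor therefore stands level with a single chlorine atom, the first direct reading of a replacement of the chloro itself. Still open, going by these compounds, is whether an amine or a carboxylic acid here would take the number beyond the scatter, and whether trifluoromethoxy would pair with the nitro of compound 3. No supporting data explain this result.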